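The source may hold more compounds than are shown below. What is called first, only, known or untested is meant among the compounds shown, and "the series" means these compounds.

Measured compounds:
- compound 1, `O=C(CCC(=O)OCCCCCCSc1ccc([N+](=O)[O-])c2nonc12)Nc1ccccc1`, 1960 nM in a functional assay on A549 cells (Homo sapiens) for inhibition, read by MTT assay, with a stated time of 72 h; a higher number here means a weaker inhibitor, a lower number a stronger inhibitor
- compound 2, `O=C(CCC(=O)OCCCCCCSc1ccc([N+](=O)[O-])c2nonc12)Nc1cccc(Cl)c1`, 5290 nM in this assay
- compound 3, `COc1ccc(NC(=O)CCC(=O)OCCCCCCSc2ccc([N+](=O)[O-])c3nonc23)cc1`, 6480 nM in this assay

Among these three, compound 3 gives the highest number, so it is the weakest inhibitor shown; its gap to compound 2 lies within the scatter, while its gap to compound 1 is beyond it.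

Compound 4 is `O=C(CCC(=O)N1CCOCC1)OCCCCCCSc1ccc([N+](=O)[O-])c2nonc12`. It differs from compound 3 by the change (morpholin-4-yl in place of (4-methoxyphenyl)amino on a carbonyl carbon). The aromatic ring that carried the amide nitrogen is gone, and with it the hydrogen-bond donor; a saturated ring takes its place.

Among the compounds with values here, none of the measured steps touches this part of the molecule. The steps of a 2.7-fold higher number from compound 1 to compound 2 (0.43 log units; beyond the scatter) and a 3.3-fold higher number from compound 1 to compound 3 (0.52 log units; beyond the scatter) only swap one ring substituent for another, and a 1.2-fold higher number from compound 2 to compound 3 (0.09 log units; within the scatter) shows that two such substituted rings hardly differ. Within the data shown here, nothing measured tells how a full exchange of the amide partner plays out, so the expectation for compound 4 is anchored on the narrow band the three known numbers occupy, with a wide range. Compound 4 is therefore expected at about 5000 nM, between 1500 nM and 16000 nM, which means an estimated step of a 1.3-fold lower number from compound 3 to compound 4 (0.11 log units; within the scatter).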

Compound 4, half-maximal inhibitory concentration: 1670 nM
Compound 4: the middle estimate sits 3.0-fold (0.48 log units) above what was measured; the measured number falls inside the stated range.
By their numbers in this assay, from the lowest: compounds 4 and 1 (each within the scatter of the next); then compounds 2 and 3 (each within the scatter of the next).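

Exchanging the whole amide partner shows that neither an aromatic ring nor the amide hydrogen is required on this carbonyl carbon for activity in these cells: morpholin-4-yl gives a 3.9-fold lower number from compound 3 to compound 4 (0.59 log units; beyond the scatter) and a 3.2-fold lower number from compound 2 to compound 4 (0.50 log units; beyond the scatter), while a 1.2-fold lower number from compound 1 to compound 4 (0.07 log units; within the scatter) shows no real difference from the plain anilino group. The higher numbers in this set therefore belong only to the two compounds with a substituted aromatic ring, compound 2 and compound 3. No available evidence accounts for these differences.

Still open, from the compounds shown here alone, is whether the oxygen of the morpholin-4-yl ring matters, which a piperidine or a piperazine in its place could test. Also open, going by these compounds, is whether an open-chain group such as dimethylamino on the same carbonyl carbon would keep the number as low as in compound 4.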